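From Compound 2 to Compound 4: A Small Chain Change

A few compounds are considered here, and "the series" means these few. Any claim that something is new, unique, unknown or untested is made for them only; others in the source may bear on it.

Compound 1 `O=S(=O)(O)OCCCCCCCCCCCC[Se]c1ccccc1` value > 100000 nM (a limit)
Compound 2 `O=S(=O)(O)OCCCCCCCC[Te]c1ccccc1` value 5990 nM
Compound 3 `O=S(=O)(O)OCCCCCCCC[Se]c1ccccc1` value > 100000 nM (a limit)

For the measured compounds named here, in a functional assay on HCT-116 cells (Homo sapiens) for cytotoxicity, read by MTT assay, with a stated time of 24 h (a higher number here means a weaker inhibitor, a lower number a stronger inhibitor), compound 2 gives 5990 nM and holds the only true number of the three. The other two entries are limits rather than numbers (the limit of > 100000 nM in this assay, at which 2 of the 3 values shown sit), which leaves compound 2 as the single measured reference point.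

Compound 4 `O=S(=O)(O)OCCCCCCCCC[Te]c1ccccc1` has not yet been measured. The change from compound 2 to compound 4 is (sulfooxy)methyl in place of sulfooxy on a saturated chain carbon, eight bonds along the chain from a tellurium atom and, cut one bond further out, it reads (sulfooxy)methyl to 2-(sulfooxy)ethyl. Going by the values given here, no measured pair shows what such a change does, so the expectation rests on compound 2 alone, with its 5990 nM as the starting point.

No change beyond the usual scatter is expected in this assay and no firm direction either, and the estimated step is a 1.1-fold lower number from compound 2 to compound 4 (0.04 log units; within the scatter) at most a modest one. For compound 4 the expected value is 5500 nM within an estimated range of 2200 nM to 14000 nM in the coming measurement.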

Compound 4, half-maximal inhibitory concentration: 4990 nM
Beside the measured number, compound 4's estimate is 1.1-fold (0.04 log units) above it; the range from low to high includes it.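

In this assay, putting (sulfooxy)methyl in place of sulfooxy on a saturated chain carbon, eight bonds along the chain from a tellurium atom, gives a 1.2-fold lower number from compound 2 to compound 4 (0.08 log units; within the scatter). For the compounds shown here, this is the first measured step at this position, and it shows that the added carbon leaves the cytotoxicity unchanged within the scatter. The tellurium series now has two true numbers, while the remaining entries offer no step to compare, because they sit at a limit: the limit of > 100000 nM in this assay, at which 2 of the 4 values shown sit.

On these data alone, it remains open whether a longer chain on the tellurium compounds would keep the number in this range. As far as these compounds go, it is also open whether a carboxylic acid or an amine could take the place of the sulfooxy group at the chain end without changing the result.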